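Phenyl in Place of Benzyl on the Ring Nitrogen

A few compounds are considered here, and "the series" means these few. Any claim that something is new, unique, unknown or untested is made for them only; others in the source may bear on it.

Of the compounds shown here, two sharing a common core have been tested in a functional assay on HeLa cells (Homo sapiens) for antiproliferative activity, read by CCK-8 assay, with a stated time of 72 h, tested at 8 uM; a lower number here means a weaker effect, a higher number a stronger effect of the compound at the concentration tested. Compound 1 `CN(Cc1ccncc1)C(=S)SCc1ccc(C(=O)Nc2ccccc2N)cc1` gives 72.7% in this assay. Compound 2 `Nc1ccccc1NC(=O)c1ccc(CSC(=S)N2CCN(Cc3ccccc3)CC2)cc1` gives 31.3% in this assay. Of these two numbers compound 2 stands lowest; its nearest neighbour, compound 1, lies higher by a gap that is beyond the usual scatter. Compound 1 and compound 2 differ in more than one place. Among the compounds with values here, no single step between them is recorded, and only their two values can be set side by side.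

Compound 3 `Nc1ccccc1NC(=O)c1ccc(CSC(=S)N2CCN(c3ccccc3)CC2)cc1` has not yet been measured. It differs from compound 2 in one place: phenyl in place of benzyl on an amine nitrogen in a ring. Within the data shown here, no measured pair in this small set shows what such an exchange does, so there is no recorded step on which to rest a prediction. The step from compound 2 to compound 3 is therefore expected to be small, a number 4.7 percentage points higher from compound 2 to compound 3 (within the scatter), quite possibly within the scatter. Compound 3 is estimated to give 36% in this assay, with an expected range from 15% to 60%.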

Compound 3, a percentage reported as inhibition, at one concentration (the size of the read-out at that concentration, not a potency): 73.1%
Compound 3: middle estimate off by 37.1 percentage points, on the low side, outside the stated range (above it).
By their numbers in this assay, from the lowest: compound 2; then compounds 1 and 3 (each within the scatter of the next).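

In this assay, the amine nitrogen in the six-membered non-aromatic ring with 2 nitrogen proves to be a sensitive place on the molecule: exchanging benzyl for phenyl there gives a number 41.8 percentage points higher from compound 2 to compound 3 (beyond the scatter), a large step that lies beyond the usual scatter. The size of this step stands out against the size of the exchange, since benzyl has 7 heavy atoms and phenyl has 6, both groups hold one six-membered aromatic ring of carbon only, and the counted hydrogen-bond donors, hydrogen-bond acceptors and net charge stay the same. Nothing available here accounts for so large a response to so small an exchange.

The compounds shown leave open whether this response is specific to an aromatic ring attached directly to the ring nitrogen, which a cyclohexyl or a pyridyl group at the same nitrogen could help to test. A longer chain, such as 2-phenylethyl, could also show whether the number keeps changing as the phenyl ring moves farther from that nitrogen, or whether the benzyl compound is a lone low point.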